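The source may hold more compounds than are shown below. What is called first, only, known or untested is meant among the compounds shown, and "the series" means these compounds.

Among the compounds with values here, compound 3 `CC(C)Cn1c(=O)n(C)c(=O)c2nc(S(=O)(=O)CCCO)c(Cc3cccc4ccccc34)nc21` gives 3750 nM in a functional assay on Raji cells (Homo sapiens) for inhibition, read by MTT assay, with a stated time of 96 h (a lower number here means that less compound is needed, a higher number that more compound is needed for the effect), the highest of the three numbers measured so far. Its nearest neighbour is compound 1 `CC(C)Cn1c(=O)n(C)c(=O)c2nc(SCCO)c(Cc3cccc4ccccc34)nc21`, which in this assay gives 2850 nM; furthest is compound 2 `CC(C)Cn1c(=O)n(C)c(=O)c2nc([S+]([O-])CCCO)c(Cc3cccc4ccccc34)nc21`, which gives 1990 nM. The steps between these three, a 1.3-fold higher number from compound 1 to compound 3 (0.12 log units; within the scatter), a 1.9-fold higher number from compound 2 to compound 3 (0.28 log units; within the scatter) and a 1.4-fold lower number from compound 1 to compound 2 (0.16 log units; within the scatter), all lie within the scatter. The next step replaces ((3-hydroxypropyl)(methyl)carbamoyl in place of (3-hydroxypropyl)sulfonyl on an aromatic carbon), giving compound 4 `CC(C)Cn1c(=O)n(C)c(=O)c2nc(C(=O)N(C)CCCO)c(Cc3cccc4ccccc34)nc21`. The measured steps only vary the sulfur-bearing chain and bear only loosely on a change to a carbamoyl, so no step beyond the scatter is expected in this assay, with wide uncertainty. Compound 4 is therefore expected to give about 3500 nM, between 1200 nM and 10000 nM, an estimated step of a 1.1-fold lower number from compound 3 to compound 4 (0.03 log units; within the scatter).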

Compound 4, half-maximal effective concentration: > 10000 nM
Compound 4 was reported as a limit; the forecaster's own chance of this, stated with the estimate: 5%; middle value at least 2.8-fold (0.45 log units) away from the limit.
By their numbers in this assay, from the lowest: compounds 2, 1 and 3 (each within the scatter of the next). At a limit, above all of these: compound 4.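

In this assay, within the data shown here, the sulfur-bearing chains on this aromatic carbon stayed within the scatter of each other, and (3-hydroxypropyl)(methyl)carbamoyl is the first group here to give steps beyond it: an at least 2.6-fold higher number from compound 3 to compound 4 (0.42 log units; beyond the scatter), an at least 3.5-fold higher number from compound 1 to compound 4 (0.54 log units; beyond the scatter) and an at least 5.0-fold higher number from compound 2 to compound 4 (0.70 log units; beyond the scatter). Compound 4 is reported only as a limit: the limit of > 10000 nM in this assay, at which 1 of the 4 values shown sits.

From the compounds shown here alone, the true size of these steps therefore remains unknown. The compounds shown leave open whether the carbonyl or the methyl-bearing amide nitrogen accounts for the step, and how an amine or a carboxylic acid on this carbon would read.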